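The source may hold more compounds than are shown below. What is called first, only, known or untested is meant among the compounds shown, and "the series" means these compounds.

In a functional assay on HUVEC cells (Homo sapiens) for cytotoxicity (a higher number here means that more compound is needed for the effect, a lower number that less compound is needed), three compounds that share one core have been measured. Compound 1 `COC1=C(C)C(=O)/C(=C(O)/C=C/c2ccc(OC)cc2)C(=O)C1(C)C` gives 2.5 ug/mL and compound 2 `COC1=C(C)C(=O)/C(=C(O)/C=C/c2ccc(C)cc2)C(=O)C1(C)C` gives 2.4 ug/mL. The step between them is a 1.0-fold lower number from compound 1 to compound 2 (0.02 log units; within the scatter), so these two values are level. Compound 3 `C=Cc1ccccc1/C=C/C(O)=C1/C(=O)C(C)=C(OC)C(C)(C)C1=O` gives 1.1 ug/mL, the lowest number of the three, meaning that less of it is needed for the effect.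

The next structure, compound 4 `COC1=C(C)C(=O)/C(=C(O)/C=C/c2cccs2)C(=O)C1(C)C`, keeps the shared core and alters one group: thiophen-2-yl in place of 2-vinylphenyl on a double-bonded chain carbon bound to a double-bonded chain carbon. Within the data shown here, no compound with thiophen-2-yl has been measured yet, so the best guides are the two steps that introduced 2-vinylphenyl. These are a 2.3-fold lower number from compound 1 to compound 3 (0.36 log units; beyond the scatter) and a 2.2-fold lower number from compound 2 to compound 3 (0.34 log units; beyond the scatter), both modest. Removing 2-vinylphenyl may therefore reverse that gain, although a new group need not behave like the two earlier ones. The expected change is a modest one toward a higher number, estimated as a 2.1-fold higher number from compound 3 to compound 4 (0.32 log units; beyond the scatter). For compound 4, the estimated value is 2.3 ug/mL, with an expected range from 1 ug/mL to 5 ug/mL.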

Compound 4, concentration for half-maximal effect: 2.5 ug/mL
The estimate for compound 4 lay 1.1-fold (0.04 log units) below the measured number; low and high end bracket the measured number.
By their numbers in this assay, from the lowest: compound 3; then compounds 2, 1 and 4 (each within the scatter of the next).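

Across this assay, the lower number of compound 3 does not carry over to the smaller thiophen-2-yl ring (a 2.3-fold higher number from compound 3 to compound 4 (0.36 log units; beyond the scatter)). Thiophen-2-yl instead stands level with 4-methylphenyl (a 1.0-fold higher number from compound 2 to compound 4 (0.02 log units; within the scatter)) and with 4-methoxyphenyl (no change at the digits printed from compound 1 to compound 4 (within the scatter)), so among these four compounds this place accepts a five-membered ring containing sulfur and two different six-membered aromatic groups with no separation in the read-out, while only 2-vinylphenyl stands apart. Nothing available here explains why 2-vinylphenyl differs from the other three groups.

On these data alone, it remains open whether the lower number depends on the vinyl group itself, which a comparison with unsubstituted phenyl or 2-ethylphenyl could help to test. As far as these compounds go, how an aromatic ring carrying an amine or a carboxylic acid would behave at this place also remains unknown.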